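Removing a chloro group on two related phenol cores

A few compounds are considered here, and "the series" means these few. Any claim that something is new, unique, unknown or untested is made for them only; others in the source may bear on it.

Measured so far:
compound 1 `OCc1cc(OCc2cc(O)ccc2O)cc(Cl)c1O` 5500 nM
compound 2 `OCc1cc(OCc2cc(O)ccc2O)ccc1O` 6400 nM
compound 3 `COCc1cc(O)cc(Cl)c1O` 64700 nM

In a functional assay on MOLT-4 cells (Homo sapiens) for cytotoxicity, read by MTT assay (a lower number here means a stronger inhibitor, a higher number a weaker inhibitor), compound 1 gives 5500 nM, and compound 2 gives 6400 nM. The change between them is hydrogen in place of chloro on an aromatic carbon, and the step was a 1.2-fold higher number from compound 1 to compound 2 (0.07 log units; within the scatter). Compound 3 gives 64700 nM in this assay; the difference between its core and the core of compound 1 is not broken down here. Compound 4 `COCc1cc(O)ccc1O` arises from compound 3 by hydrogen in place of chloro on an aromatic carbon. This is the same kind of change as from compound 1 to compound 2, though not the same: there the position was meta to a hydroxymethyl group and meta to a large group, here it is meta to a hydroxy group and meta to a methoxymethyl group. Because the earlier step was a 1.2-fold higher number from compound 1 to compound 2 (0.07 log units; within the scatter), the step of a 1.1-fold higher number from compound 3 to compound 4 (0.05 log units; within the scatter) is expected to be similarly small. Compound 4 is therefore estimated at 72000 nM in this assay, between 30000 nM and 170000 nM.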

Compound 4, half-maximal inhibitory concentration: 86200 nM
Estimate against measurement, compound 4: 1.2-fold (0.08 log units) below, within the range that was stated.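

In this assay the new step is a 1.3-fold higher number from compound 3 to compound 4 (0.12 log units; within the scatter) and it sits close to the earlier one: the same change on two cores in this assay, a 1.2-fold higher number (0.07 log units; within the scatter) from compound 1 to compound 2 and a 1.3-fold higher number (0.12 log units; within the scatter) from compound 3 to compound 4, 1.1-fold (0.06 log units) apart, within the scatter of two such steps. So on these two cores, swapping chloro for hydrogen carries over consistently, staying within the scatter on both the larger and the smaller core. Going by these compounds alone, this rests on only two pairs, and since neither step goes beyond the scatter, the data show no measurable effect of the swap rather than a shared effect of known size, and they cannot speak for other cores.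

The compounds shown leave open what a different group in that place, such as a fluoro, a methyl or an amine, would do. They also leave open whether a chloro group matters on any other core.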